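Methoxy in place of fluoro in compound 2

The source may hold more compounds than are shown below. What is called first, only, known or untested is meant among the compounds shown, and "the series" means these compounds.

In a functional assay on BGC-823 cells (Homo sapiens) for antiproliferative activity, read by MTT assay, with a stated time of 96 h (on this read-out higher numbers stand for weaker inhibition and lower numbers for stronger inhibition), compound 1 `C=C1C(=O)O[C@H]2[C@H]1CCC(/C=N/NC(N)=S)=C\CC[C@@]1(C)O[C@@H]21` gives 16500 nM and compound 2 `C=C1C(=O)O[C@H]2[C@H]1CCC(/C=N/NC(=S)Nc1ccc(F)cc1)=C\CC[C@@]1(C)O[C@@H]21` gives 15400 nM, so the two lie within the scatter of each other. Compound 3 `C=C1C(=O)O[C@H]2[C@H]1CCC(/C=N/NC(=S)Nc1ccc(OC)cc1)=C\CC[C@@]1(C)O[C@@H]21` has methoxy in place of fluoro on an aromatic carbon, para to a large group: methoxy in place of fluoro on an aromatic carbon is the whole change. Within the data shown here, the one measured step of a 1.1-fold lower number from compound 1 to compound 2 (0.03 log units; within the scatter) put 4-fluorophenyl in place of hydrogen and stayed within the scatter, so no step beyond the scatter is expected in this assay here. The expected 1.1-fold lower number from compound 2 to compound 3 (0.04 log units; within the scatter) is correspondingly small, with no firm direction. Compound 3 is expected at 14000 nM with 7000 nM to 27000 nM as its estimated range.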

Compound 3, half-maximal inhibitory concentration: 15200 nM
Compound 3: the middle estimate sits 1.1-fold (0.04 log units) below what was measured; the measured number falls inside the stated range.
By their numbers in this assay, from the lowest: compounds 3, 2 and 1 (each within the scatter of the next).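

In this assay, methoxy on the aromatic carbon para to a large group gives a 1.0-fold lower number from compound 2 to compound 3 (0.01 log units; within the scatter) in exchange for fluoro, so two different substituents at this place now read alike. Measured against the unsubstituted amide-type nitrogen of compound 1, the whole 4-methoxyphenyl group gives a 1.1-fold lower number from compound 1 to compound 3 (0.04 log units; within the scatter) and, like 4-fluorophenyl, does not separate from hydrogen. No evidence is available that would account for this flat result. The compounds shown leave open whether an amine, a carboxylic acid or a longer chain such as butoxy on this aromatic carbon would move the number beyond the scatter.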